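Swapping chloro for methoxy in a weak alpha-1D series

The compounds below may be only part of what the source reports. "The series", "measured", "known", "first", "only" and "open" are said of these compounds alone.

Measured so far in a functional assay on CHO cells for agonist activity at Alpha-1D adrenergic receptor (Homo sapiens), read by FLIPR and calcium flux; on this read-out higher numbers stand for an effect only at larger amounts of compound and lower numbers for an effect already at smaller amounts:
compound 1, `COCc1ccccc1C1CCc2nc[nH]c2C1`: > 10000 nM; > 10000 nM (2 entries)
compound 2, `Clc1ccccc1C1CCc2nc[nH]c2C1`: > 10000 nM

Compound 2 does not give a number in this assay; its result is only a limit, (the limit of > 10000 nM in this assay, at which 1 of the 2 values shown sits). Compound 1 likewise shows only a limit in this assay, so neither compound gives a point from which a direction could be read.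

Compound 3, `COc1ccccc1C1CCc2nc[nH]c2C1`, is the next compound to be measured in this assay. It differs from compound 2 in one place: methoxy in place of chloro on an aromatic carbon. Among the compounds with values here, no measured pair shows what such a change does here, so the expected step can rest only on the fact that both measured compounds sit at the limit. The step that the limit leaves unreadable from compound 2 to compound 3 is therefore expected to be small, with no direction beyond the scatter, and most likely another limit. Compound 3 is expected at about 20000 nM, in a range from 7000 nM to 60000 nM.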

Compound 3, half-maximal effective concentration: 3500 nM
Compound 3: the middle estimate sits 5.7-fold (0.76 log units) above what was measured; the measured number lies below the stated range.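

In this assay, compound 3 is the first of the compounds shown to give a real number rather than a limit, so this series can reach a measurable effect. Putting methoxy in place of chloro on this aromatic carbon gives an at least 2.8-fold lower number from compound 2 to compound 3 (0.45 log units; beyond the scatter), and a lower number here means that a smaller amount of compound is enough for the effect. This is the first sign that the group at this place matters, but the full size of the step cannot be read because compound 2 gives only a limit: the limit of > 10000 nM in this assay, at which 1 of the 3 values shown sits.

A single pair cannot say which feature of methoxy counts, whether its oxygen, which brings the one hydrogen-bond acceptor, or its extra carbon. From the compounds shown here alone, how a hydroxy, an ethoxy or an amine at this place would fare also remains open.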